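The source may report more compounds than this note shows. Statements on the series, on what has been measured and on what is new or still open speak of the compounds shown alone.

Compound 1 `COc1ccc(NS(=O)(=O)/C=C/c2ccc(OC)cc2OC)cc1`: 15000 nM
Compound 2 `COc1ccc(NS(=O)(=O)/C=C/c2c(OC)cc(OC)cc2OC)cc1`: 200 nM

Both values come from a functional assay on DU-145 cells (Homo sapiens) for cytotoxicity, read by trypan blue exclusion, with a stated time of 96 h; on this read-out higher numbers stand for weaker inhibition and lower numbers for stronger inhibition. Compound 2 has the lower of the two numbers, which makes it the stronger inhibitor of this pair. Compound 3 `COc1cc(OC)c(/C=C/S(=O)(=O)Nc2ccc(OC)c(N)c2)c(OC)c1` keeps the core of compound 2 with a single change: amino in place of hydrogen on an aromatic carbon. This places amino in place of hydrogen on an aromatic carbon, turning 4-methoxyphenyl into 3-amino-4-methoxyphenyl.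

For the measured compounds named here, only one measured step bears on this change, and only loosely. The step of a 75-fold lower number from compound 1 to compound 2 (1.88 log units; beyond the scatter) was large, but it brought in methoxy, not amino, on a different part of the molecule. It shows that one substitution can move the number strongly in this pair, yet no measurement tests amino itself. A modest move towards a lower number is therefore expected, with real doubt about its direction. The expected change is a 2.9-fold lower number from compound 2 to compound 3 (0.46 log units; beyond the scatter). For compound 3 the estimated value is 70 nM, with an expected range from 10 nM to 400 nM.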

Compound 3, half-maximal inhibitory concentration: 5 nM
Compound 3: the middle estimate sits 14-fold (1.15 log units) above what was measured, outside the stated range (below it).
By their numbers in this assay, from the lowest: compound 3; then compound 2; then compound 1.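

Placing amino on the aromatic carbon ortho to a methoxy group, which turns 4-methoxyphenyl into 3-amino-4-methoxyphenyl, brings a 40-fold lower number from compound 2 to compound 3 (1.60 log units; beyond the scatter) in this assay and so shows that this part of the molecule also responds strongly to a single change. The earlier large step came from methoxy on a different part of the molecule, so it said nothing about this position or about amino. Here, one entering heavy atom is enough for a large step, but nothing measured explains its size.

The compounds shown leave open how a hydroxyl or a methylamino group on the same carbon would compare with amino. They also leave open whether amino at this place would bring a similar step on the core of compound 1.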